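Swapping Benzyloxy for Benzamido on a Shared Core

A few compounds are considered here, and "the series" means these few. Any claim that something is new, unique, unknown or untested is made for them only; others in the source may bear on it.

Of the compounds shown here, two built on a shared core have been measured so far. Among the measured compounds shown here, compound 1 `CN(c1ccccc1)c1ccc2oc(-c3cc(-c4cnn(C5CCNCC5)c4)cnc3N)nc2c1` and compound 2 `Nc1ncc(-c2cnn(C3CCNCC3)c2)cc1-c1nc2ccc(OCc3ccccc3)cc2o1` differ from each other in more than one place, so no single step between them is described. In an assay on isolated protein for inhibition of G protein-coupled receptor kinase 5 (Homo sapiens), read by TR-FRET, with stated times of 10 min and 1 h (a higher number here means a weaker inhibitor, a lower number a stronger inhibitor), compound 1 gives 5050 nM. In this assay compound 2 gives 6900 nM, the higher of the two numbers, although the gap to compound 1 lies within the scatter of repeated measurements, so the two cannot be ordered. Compound 3 `Nc1ncc(-c2cnn(C3CCNCC3)c2)cc1-c1nc2ccc(NC(=O)c3ccccc3)cc2o1` has not yet been measured; it carries benzamido in place of benzyloxy on an aromatic carbon. For the measured compounds named here, no measured pair shows what this kind of change does on this core, so there is no basis for expecting a step beyond the scatter in either direction. Compound 3 is therefore expected to give about 5500 nM, within a range from 1500 nM to 20000 nM. That estimate means a 1.3-fold lower number from compound 2 to compound 3 (0.10 log units; within the scatter) in this assay, a step expected to stay within the scatter.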

Compound 3, half-maximal inhibitory concentration: 3490 nM
Beside the measured number, compound 3's estimate is 1.6-fold (0.20 log units) above it, and the stated range covers the measured number.
By their numbers in this assay, from the lowest: compounds 3, 1 and 2 (each within the scatter of the next).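

Among the compounds shown here, this is the first pair on the shared core that differs in one place, and with benzamido in place of benzyloxy on an aromatic carbon, this assay shows a 2.0-fold lower number from compound 2 to compound 3 (0.30 log units; within the scatter). The swap keeps the six-membered aromatic ring of carbon only and adds a hydrogen-bond donor, yet the number does not move beyond what repeated measurements would show, so this single pair reveals no effect of the change at this position. Nothing available explains the size of this step.

Still open, as far as these compounds go, is whether a different group on this carbon, such as a simple amine, a carboxylic acid or a longer alkyl chain, would give a step beyond the scatter. The compounds shown also leave open whether the aromatic ring of benzamido matters at all, since both groups in this pair carry one.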